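Fluoro in place of methyl on compound 3

This account rests on a few compounds, and the source may have more. Where it says the series, first, only, none or still open, it means among the compounds named here.

Measured in a functional assay, read by spectrophotometry, tested at 100 uM; a lower number here means a stronger inhibitor, a higher number a weaker inhibitor:
compound 1 `O=C(/C=C/c1ccccc1)c1cccc(NC(=O)c2cc(-c3ccncc3)n[nH]2)c1`: 67100 nM
compound 2 `O=C(/C=C/c1cccc2ccccc12)c1cccc(NC(=O)c2cc(-c3ccncc3)n[nH]2)c1`: 64500 nM
compound 3 `Cc1ccc(/C=C/C(=O)c2cccc(NC(=O)c3cc(-c4ccncc4)n[nH]3)c2)cc1`: 69400 nM

Compound 3 gives 69400 nM, and it cannot be told apart from the other two compounds: the data show a 1.0-fold higher number from compound 1 to compound 3 (0.01 log units; within the scatter) and a 1.1-fold higher number from compound 2 to compound 3 (0.03 log units; within the scatter). The next compound is compound 4 `O=C(/C=C/c1ccc(F)cc1)c1cccc(NC(=O)c2cc(-c3ccncc3)n[nH]2)c1`, which carries fluoro in place of methyl on an aromatic carbon, para to a large group: fluoro in place of methyl on an aromatic carbon. Among the measured compounds shown here, no measured compound carries fluoro, so no step speaks to this change directly. The nearest evidence is indirect. Methyl in place of hydrogen on an aromatic carbon gave a 1.0-fold higher number from compound 1 to compound 3 (0.01 log units; within the scatter), and naphthalen-1-yl in place of phenyl gave a 1.0-fold lower number from compound 1 to compound 2 (0.02 log units; within the scatter). Neither step left the scatter, although three compounds are a narrow basis. In this assay the expected step is a 1.0-fold lower number from compound 3 to compound 4 (0.01 log units; within the scatter), so none beyond the scatter is anticipated. For compound 4 the estimated value is 68000 nM, with an expected range of 42000 nM to 100000 nM.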

Compound 4, half-maximal inhibitory concentration: 56000 nM
Compound 4: the middle estimate sits 1.2-fold (0.08 log units) above what was measured; the measured number falls inside the stated range.
By their numbers in this assay, from the lowest: compounds 4, 2, 1 and 3 (each within the scatter of the next).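

In this assay, fluoro in place of methyl gives a 1.2-fold lower number from compound 3 to compound 4 (0.09 log units; within the scatter) and fluoro in place of hydrogen gives a 1.2-fold lower number from compound 1 to compound 4 (0.08 log units; within the scatter) so hydrogen, methyl and fluoro on this aromatic carbon, para to a large group, cannot be told apart. The 4-fluorophenyl group likewise cannot be told apart from naphthalen-1-yl, with a 1.2-fold lower number from compound 2 to compound 4 (0.06 log units; within the scatter) and the four compounds remain a single group in this assay. Nothing available offers an explanation for this result.

As far as these compounds go, whether this aromatic carbon responds to any group at all stays open, since an amine, a carboxylic acid or a longer chain here might yet stand apart from these four compounds. Every change shown also sits at the same end of the molecule, leaving open how changes to the shared core would read.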